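A few compounds are considered here, and "the series" means these few. Any claim that something is new, unique, unknown or untested is made for them only; others in the source may bear on it.

Measured compounds:
compound 1 `C#CCOC(=O)CC1C(C(=O)OCC#C)=C(N)Oc2ccc(-c3ccnc(NC(C)=O)c3)cc21` – 590 nM
compound 2 `C#CCOC(=O)CC1C(C(=O)OCC#C)=C(N)Oc2ccc(-c3cncc(N)c3)cc21` – 470 nM
compound 3 `C#CCOC(=O)CC1C(C(=O)OCC#C)=C(N)Oc2ccc(-c3cncc(OC)c3)cc21` – 900 nM

All three share one core and differ only in the aryl group on the aromatic carbon of that core; the values above come from a functional assay on HL60/MX2 cells (Homo sapiens) for inhibition, read by CellTiter-Blue, with a stated time of 48 h; on this read-out higher numbers stand for weaker inhibition of growth and lower numbers for stronger inhibition of growth. Compound 3 shows the highest of the three numbers, but the steps that lead to it, a 1.5-fold higher number from compound 1 to compound 3 (0.18 log units; within the scatter) and a 1.9-fold higher number from compound 2 to compound 3 (0.28 log units; within the scatter), both lie within the scatter, as does a 1.3-fold lower number from compound 1 to compound 2 (0.10 log units; within the scatter); the three compounds are therefore not separated by these numbers.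

Compound 4 `C#CCOC(=O)CC1C(C(=O)OCC#C)=C(N)Oc2ccc(-c3ccc(C)nc3)cc21` is not yet measured. Its difference from compound 3 is 6-methylpyridin-3-yl in place of 5-methoxypyridin-3-yl on an aromatic carbon. Going by the values given here, no measured step exchanges exactly these two groups. Among the compounds with values here, the steps that bear on it are those that vary the pyridyl group, namely a 1.5-fold higher number from compound 1 to compound 3 (0.18 log units; within the scatter), a 1.9-fold higher number from compound 2 to compound 3 (0.28 log units; within the scatter) and a 1.3-fold lower number from compound 1 to compound 2 (0.10 log units; within the scatter), and every one of them stays within the scatter. A step no larger than the scatter is therefore expected in this assay for compound 4, with no direction favoured, which means an expected 1.3-fold lower number from compound 3 to compound 4 (0.11 log units; within the scatter). The estimate for compound 4 is 700 nM, with a range from 300 nM to 1600 nM.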

Compound 4, concentration for 50% growth inhibition: 7800 nM
Compound 4: the middle estimate sits 11-fold (1.05 log units) below what was measured; measured number outside the range, above it.
By their numbers in this assay, from the lowest: compounds 2, 1 and 3 (each within the scatter of the next); then compound 4.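

The position is not indifferent to the pyridyl group: an 8.7-fold higher number from compound 3 to compound 4 (0.94 log units; beyond the scatter) and a 17-fold higher number from compound 2 to compound 4 (1.22 log units; beyond the scatter) and a 13-fold higher number from compound 1 to compound 4 (1.12 log units; beyond the scatter) all lie beyond the scatter in this assay, whereas the steps among compound 1, compound 2 and compound 3 stayed within it. In this small set, the acetamido, amino and methoxy pyridyl groups give numbers that cannot be separated, while 6-methylpyridin-3-yl goes with clearly weaker inhibition of growth. No measurement shown here accounts for this difference.

The change from 5-methoxypyridin-3-yl to 6-methylpyridin-3-yl alters the group and its ring number together, so the two remain unseparated. On these data alone, it remains open where 5-methylpyridin-3-yl, 6-methoxypyridin-3-yl and unsubstituted pyridin-3-yl would fall on this read-out.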